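This account rests on a few compounds, and the source may have more. Where it says the series, first, only, none or still open, it means among the compounds named here.

Compound 1 `COc1cc(NC(C)CCCNC(=O)NNC(=O)Nc2cccc(F)c2)c2ncccc2c1`: 69000 nM
Compound 2 `COc1cc(NC(C)CCCNC(=O)NNC(=O)Nc2ccc(Br)cc2)c2ncccc2c1`: 231000 nM
Compound 3 `COc1cc(NC(C)CCCNC(=O)Nc2ccc(C(F)(F)F)cc2)c2ncccc2c1`: 8400 nM

All three were tested in a functional assay on MIA PaCa-2 cells (Homo sapiens) for inhibition, read by MTT assay, with a stated time of 72 h; on this read-out lower numbers stand for stronger inhibition and higher numbers for weaker inhibition. Compound 1 stands second highest of these numbers: compound 2 sits above it by a 3.3-fold higher number from compound 1 to compound 2 (0.52 log units; beyond the scatter), while compound 3 sits below it by an 8.2-fold lower number from compound 1 to compound 3 (0.91 log units; beyond the scatter). The unmeasured compound 4 `COc1cc(NC(C)CCCNC(=O)Nc2ccc(Br)cc2)c2ncccc2c1` differs from compound 1 in one place: 4-bromophenyl in place of ((3-fluorophenyl)carbamoyl)amino on an amide-type nitrogen. Within the data shown here, two measured steps bear on this change. Putting an aryl group directly on the amide-type nitrogen in place of a carbamoylamino-linked one gave an 8.2-fold lower number from compound 1 to compound 3 (0.91 log units; beyond the scatter) and a 28-fold lower number from compound 2 to compound 3 (1.44 log units; beyond the scatter), both pointing the same way. Since compound 2 gives 231000 nM where compound 1 gives 69000 nM, the 4-bromophenyl version may not reach compound 3. A lower number beyond the scatter is nonetheless expected for compound 4, an expected step of a 4.6-fold lower number from compound 1 to compound 4 (0.66 log units; beyond the scatter). Compound 4 is therefore estimated at 15000 nM, with a range from 5000 nM to 45000 nM.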

Compound 4, half-maximal inhibitory concentration: 23000 nM
Compound 4: middle estimate off by 1.5-fold (0.19 log units), on the low side; the range from low to high includes it.
By their numbers in this assay, from the lowest: compound 3; then compound 4; then compound 1; then compound 2.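

Among these compounds, compound 2 and compound 4 carry the same 4-bromophenyl, so removing the carbamoylamino link is the only change in the step of a 10-fold lower number from compound 2 to compound 4 (1.00 log units; beyond the scatter), and it isolates the effect of that link. The step of a 3.0-fold lower number from compound 1 to compound 4 (0.48 log units; beyond the scatter), which also changes the ring, points the same way. On the directly attached ring, the step of a 2.7-fold higher number from compound 3 to compound 4 (0.44 log units; beyond the scatter), with bromo in place of trifluoromethyl, shows that the ring substituent matters too.

No measurement shown explains either effect. As far as these compounds go, how an amine or a carboxylic acid on this ring would compare remains open.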